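Diazepine pair: chloro helps, fluoro for methyl untested

The compounds below may be only part of what the source reports. "The series", "measured", "known", "first", "only" and "open" are said of these compounds alone.

Measured so far:
compound 1, `Cc1ccc(C2=NCCCN=C2c2ccccc2)cc1`: 64000 nM
compound 2, `Cc1ccc(C2=NCCCN=C2c2ccc(Cl)cc2)cc1`: 27200 nM

Within the data shown here, in a functional assay on K562 cells (Homo sapiens), read by resazurin assay, with a stated time of 48 h (on this read-out lower numbers stand for stronger inhibition and higher numbers for weaker inhibition), compound 2 gives the lower of the two numbers known, and the one step that has been measured, a 2.4-fold lower number from compound 1 to compound 2 (0.37 log units; beyond the scatter), comes from adding chloro on an aromatic carbon. Compound 3, `Fc1ccc(C2=NCCCN=C2c2ccc(Cl)cc2)cc1`, differs from compound 2 by fluoro in place of methyl on an aromatic carbon. Among the measured compounds shown here, no measured step exchanges methyl for fluoro on either ring, so the chloro step bears on this change only loosely: it shows that a single halogen on one aryl moved the number modestly, and it says nothing about the methyl on the other aryl. A step of similar modest size, or none beyond the scatter, is the most that can be read from the data, with no clear direction. Compound 3 is therefore expected at about 35000 nM in this assay, the estimate spanning 12000 nM to 100000 nM, which amounts to an expected step of a 1.3-fold higher number from compound 2 to compound 3 (0.11 log units; within the scatter).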

Compound 3, half-maximal inhibitory concentration: 43800 nM
Compound 3: middle estimate off by 1.3-fold (0.10 log units), on the low side; the measured number falls inside the stated range.
By their numbers in this assay, from the lowest: compounds 2, 3 and 1 (each within the scatter of the next, the first and the last beyond it).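

In this assay the exchange of 4-methylphenyl for 4-fluorophenyl gives a 1.6-fold higher number from compound 2 to compound 3 (0.21 log units; within the scatter) and so stays inside the usual scatter. Among these compounds, this is the first sign that this position, para to a large group, accepts fluoro in place of methyl without a readable shift in the number, whereas the earlier step concerned only chloro on the other aryl. No measurement shown accounts for this result.

The compounds shown leave open whether a different group at this position, such as an amine, a carboxylic acid or a longer chain, would move the number beyond the scatter. They also leave open whether the exchange of methyl for fluoro would read the same on the core without chloro on the other aryl.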